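The source may hold more compounds than are shown below. What is called first, only, known or untested is meant among the compounds shown, and "the series" means these compounds.

Measured so far:
- compound 1, `Cc1cc(-c2nc(C(F)(F)F)n(CC[C@@H](O)C[C@@H](O)CC(=O)O)c2-c2ccc(F)cc2)cc(C)c1F`: 32 nM
- compound 2, `O=C(O)C[C@H](O)C[C@H](O)CCn1c(C(F)(F)F)nc(-c2cccs2)c1-c1ccc(F)cc1`: 64 nM
- compound 3, `Cc1cc(-c2c(-c3ccc(F)cc3)nc(C(F)(F)F)n2CC[C@@H](O)C[C@@H](O)CC(=O)O)cc(C)c1F`: 31 nM

All three compounds were tested in an assay on microsomes from liver for inhibition of 3-hydroxy-3-methylglutaryl-coenzyme A reductase (Rattus norvegicus); on this read-out lower numbers stand for stronger inhibition and higher numbers for weaker inhibition. Compound 1 and compound 2 share a core and differ in one place: thiophen-2-yl in place of 4-fluoro-3,5-dimethylphenyl on an aromatic carbon. That change gave a 2.0-fold higher number from compound 1 to compound 2 (0.30 log units; within the scatter), so the two values cannot be told apart with confidence.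

Compound 3 is built from the same atoms as compound 1, joined differently; the difference between the two cores is not broken down here. In this assay compound 3 gives 31 nM, and compound 1 gives 32 nM, two numbers within the scatter of each other.

Compound 4, `O=C(O)C[C@H](O)C[C@H](O)CCn1c(C(F)(F)F)nc(-c2ccc(F)cc2)c1-c1cccs1`, has not yet been measured. It is related to compound 3 by the same kind of change that turns compound 1 into compound 2: thiophen-2-yl in place of 4-fluoro-3,5-dimethylphenyl on an aromatic carbon. The surroundings are not identical, though. In compound 1 the replaced group sits two ring bonds from the ring atom that bears the 6-carboxy-3,5-dihydroxyhexyl group, while in compound 3 it sits next to that ring atom.

Going by the values given here, with only one earlier example of this change, the expectation for compound 4 rests on the step from compound 1 to compound 2 and on the value of compound 3. Compound 4 is therefore expected to show a 2.0-fold higher number from compound 3 to compound 4 (0.30 log units; within the scatter) in this assay. The estimated value for compound 4 is 62 nM, with a likely range from 30 nM to 130 nM.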

Compound 4, half-maximal inhibitory concentration: 215 nM
Compound 4: middle estimate off by 3.5-fold (0.54 log units), on the low side; measured number outside the range, above it.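

In this assay, placing thiophen-2-yl where 4-fluoro-3,5-dimethylphenyl stood, on the ring carbon next to the ring atom that bears the 6-carboxy-3,5-dihydroxyhexyl group, gave a 6.9-fold higher number from compound 3 to compound 4 (0.84 log units; beyond the scatter). This swap therefore clearly weakened inhibition on the core of compound 3, and the result on the core of compound 1 did not predict the size of that step, so the change cannot be carried between these two cores as one fixed amount: the same change on two cores in this assay, a 2.0-fold higher number (0.30 log units; within the scatter) from compound 1 to compound 2 and a 6.9-fold higher number (0.84 log units; beyond the scatter) from compound 3 to compound 4, 3.5-fold (0.54 log units) apart, beyond the scatter of two such steps. Going by these compounds alone, with only two pairs, this shows that the surroundings of the swap matter here, but it does not show which feature of the two cores is responsible or how the same swap would behave on a third core.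

The compounds shown leave open whether the larger step on the core of compound 3 is tied to thiophen-2-yl itself or would also appear with another group at this place, such as furan-2-yl, a pyridine ring or a phenyl ring without the two methyl groups. They also leave open whether the gap between the two steps would persist if the trifluoromethyl group on both cores were replaced by a methyl group.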